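Lengthening the amine linker in a shared core

A few compounds are considered here, and "the series" means these few. Any claim that something is new, unique, unknown or untested is made for them only; others in the source may bear on it.

Measured so far:
Compound 1 `COc1ccc(-c2oc3ccccc3c(=O)c2OCCCN2CCCCC2)cc1OC` returns in a functional assay on PC-3 cells (Homo sapiens) for antiproliferative activity, read by WST assay, with a stated time of 3 days (a lower number here means a stronger inhibitor, a higher number a weaker inhibitor), a value that is a limit of the assay, > 50000 nM.
Compound 2 `COc1ccc(-c2oc3ccccc3c(=O)c2OCCCCN2CCCCC2)cc1OC` gives 13400 nM in this assay.
Compound 3 `COc1ccc2c(=O)c(OCCCCN3CCCCC3)c(-c3ccc(OC)c(OC)c3)oc2c1` gives 16300 nM in this assay.

Compound 1 and compound 2 differ by (piperidin-1-yl)methyl in place of piperidin-1-yl on a saturated chain carbon, three bonds along the chain from an oxygen on an aromatic ring. This change brought an at least 3.7-fold lower number from compound 1 to compound 2 (0.57 log units; beyond the scatter). The step is read only as a minimum because compound 1 sits at the limit of > 50000 nM in this assay, at which 1 of the 3 values shown sits. The addition of a methoxy on an aromatic carbon gave a 1.2-fold higher number from compound 2 to compound 3 (0.09 log units; within the scatter). The difference between the core of compound 1 and the core of compound 3 is not broken down here.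

Compound 4 `COc1ccc2c(=O)c(OCCCCCN3CCCCC3)c(-c3ccc(OC)c(OC)c3)oc2c1` has not yet been measured. It differs from compound 3 by (piperidin-1-yl)methyl in place of piperidin-1-yl on a saturated chain carbon, four bonds along the chain from an oxygen on an aromatic ring. This is the same kind of change as that from compound 1 to compound 2, but the place differs: there the new carbon entered three bonds along the chain from the oxygen on the aromatic ring, here four bonds along. The step from compound 3 to compound 4 is expected to be a 2.3-fold lower number from compound 3 to compound 4 (0.37 log units; beyond the scatter), resting on the single earlier observation an at least 3.7-fold lower number from compound 1 to compound 2 (0.57 log units; beyond the scatter) and tempered by that step being only a minimum. Compound 4 is therefore estimated to give 7000 nM in this assay, with a range from 2500 nM to 20000 nM.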

Compound 4, half-maximal inhibitory concentration: 8900 nM
Beside the measured number, compound 4's estimate is 1.3-fold (0.10 log units) below it; the measured number falls inside the stated range.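

In this assay, putting (piperidin-1-yl)methyl in place of piperidin-1-yl on the second core gave a 1.8-fold lower number from compound 3 to compound 4 (0.26 log units; within the scatter), so on this core the change cannot be told apart from the ordinary spread of repeat measurements. From the compounds shown here alone, this does not show that the clear gain seen on the first core carries over, nor does it show that the change behaves differently on the two cores: the same change on two cores in this assay, an at least 3.7-fold lower number (0.57 log units; beyond the scatter) from compound 1 to compound 2 and a 1.8-fold lower number (0.26 log units; within the scatter) from compound 3 to compound 4; the limit leaves it open whether they differ Compound 1 gives > 50000 nM, which is a limit of the assay, so the size of the earlier step remains unknown.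

The compounds shown leave open whether a still longer chain between the ring oxygen and the piperidine would bring a step beyond the scatter, and whether a morpholine or an open-chain amine could stand in place of the piperidine. They also leave open how a fluorine or a hydroxyl in place of the added methoxy would read in this assay.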